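The compounds below may be only part of what the source reports. "The series", "measured", "known", "first", "only" and "open" are said of these compounds alone.

Measured in a functional assay on PC-3 cells (Homo sapiens) for antiproliferative activity, read by MTT assay, with a stated time of 72 h; on this read-out lower numbers stand for stronger inhibition and higher numbers for weaker inhibition:
compound 1 `O=C(N/N=C/c1ccc(Br)cc1)Nc1ccc(Oc2ccnc3[nH]ccc23)c(F)c1`: 920 nM
compound 2 `COc1ccc(/C=N/NC(=O)Nc2ccc(Oc3ccnc4[nH]ccc34)c(F)c2)cc1`: 6730 nM
compound 3 `O=C(N/N=C/c1ccc(Br)cc1)Nc1ccc(Oc2ccnc3[nH]ccc23)cc1`: "not active" (no number reported)

In this assay compound 3 is reported as "not active" (no number reported), so it offers no number to start from. Compound 4 `COc1ccc(/C=N/NC(=O)Nc2ccc(Oc3ccnc4[nH]ccc34)cc2)cc1` differs from it in one place: methoxy in place of bromo on an aromatic carbon. Among the measured compounds shown here, the only measured step with this same change, methoxy in place of bromo on an aromatic carbon, is a 7.3-fold higher number from compound 1 to compound 2 (0.86 log units; beyond the scatter). That step is modest and points towards weaker inhibition. No gain is therefore expected in this assay, and a step to a higher number is the likelier outcome, though its size from compound 3 cannot be stated. A report without any number is quite possible. The estimated value for compound 4 is 15000 nM, expected to fall between 5000 nM and 60000 nM.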

Compound 4, half-maximal inhibitory concentration: "not active" (no number reported)
For compound 4 the study gives words and no number; there is nothing to compare the estimate with.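

In this assay compound 3 and compound 4 both come without a number, so no step can be read between them. On these data alone, whether 4-bromophenyl to 4-methoxyphenyl changes anything in this pair stays open. No supporting data explain the result.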